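This account rests on a few compounds, and the source may have more. Where it says the series, first, only, none or still open, it means among the compounds named here.

The series shares one core. Compound 1 `CCCSc1nc(N/N=C(\C)c2ccccc2O)c2nnn(Cc3ccco3)c2n1` carries furan-2-yl on the saturated chain carbon bound to an aromatic nitrogen, compound 2 `CCCSc1nc(N/N=C(\C)c2ccccc2O)c2nnn(Cc3cccc(Cl)c3)c2n1` carries 3-chlorophenyl there, and compound 3 `CCCSc1nc(N/N=C(\C)c2ccccc2O)c2nnn(Cc3ccc(F)cc3)c2n1` carries 4-fluorophenyl. In a functional assay on MCF7 cells (Homo sapiens) for antiproliferative activity, read by MTT assay, with a stated time of 72 h (on this read-out higher numbers stand for weaker inhibition and lower numbers for stronger inhibition), compound 1 gives 29000 nM and compound 2 gives 39900 nM, a step of a 1.4-fold higher number from compound 1 to compound 2 (0.14 log units; within the scatter). Compound 3 reaches only a limit of the assay, > 64000 nM. Among the values shown, (the limit of > 64000 nM in this assay, at which 1 of the 3 values shown sits). The steps toward compound 3 are an at least 2.2-fold higher number from compound 1 to compound 3 (0.34 log units; beyond the scatter) and an at least 1.6-fold higher number from compound 2 to compound 3 (0.20 log units; that floor lies within the scatter), so compound 3 stands with a limit rather than a number, and the whole set sits in the high range of this assay.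

Compound 4 `CCCSc1nc(N/N=C(\C)c2ccccc2O)c2nnn(Cc3ccc(O)cc3)c2n1` differs from compound 3 by hydroxy in place of fluoro on an aromatic carbon. Going by the values given here, none of the measured steps bears directly on this exchange: each of them swaps the whole group on the saturated chain carbon, and no hydroxy appears anywhere in the measured set. With compound 3 already at the limit, no step beyond the scatter is expected in this assay in either direction. Compound 4 is therefore estimated at 60000 nM, within 25000 nM to 150000 nM, an expected step of an at least 1.0-fold lower number from compound 3 to compound 4 (0.02 log units; that floor lies within the scatter).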

Compound 4, half-maximal inhibitory concentration: 9520 nM
The estimate for compound 4 lay 6.3-fold (0.80 log units) above the measured number, and the stated range ends above it.
By their numbers in this assay, from the lowest: compound 4; then compounds 1 and 2 (each within the scatter of the next). At a limit, above all of these: compound 3.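

Hydroxy in place of fluoro on the aromatic carbon gives an at least 6.7-fold lower number from compound 3 to compound 4 (0.82 log units; beyond the scatter) in this assay, and that size is only a floor, since compound 3 stands at a limit: the limit of > 64000 nM in this assay, at which 1 of the 4 values shown sits. With 4-hydroxyphenyl on the saturated chain carbon, the number also falls against the other two groups, with a 4.2-fold lower number from compound 2 to compound 4 (0.62 log units; beyond the scatter) and a 3.0-fold lower number from compound 1 to compound 4 (0.48 log units; beyond the scatter), so this group gives the lowest number of the set, with each step beyond the scatter. Going by these compounds alone, the other swaps at this position held or raised the number, which makes hydroxy the one change here that lowers it.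

On these data alone, whether this drop is specific to hydroxy stays open: an amine or a methoxy at the same place would test that. The rest of the core is the same in all four compounds, so nothing shows whether the step carries over to a different core.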